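One Methyl Step, Repeated on a Second Core

A few compounds are considered here, and "the series" means these few. Any claim that something is new, unique, unknown or untested is made for them only; others in the source may bear on it.

Measured compounds and their values:
compound 1 `COc1ccc(C(=O)NNC(=S)Nc2csc(-c3ccccc3)c2)cc1OC` gives 28000 nM
compound 2 `COc1ccc(C(=O)NNC(=S)Nc2csc(-c3ccc(C)cc3)c2)cc1OC` gives 19000 nM
compound 3 `Oc1ccc(-c2nnc(Nc3csc(-c4ccccc4)c3)s2)cc1` gives 57000 nM

All three were tested in a functional assay on SK-MEL-28 cells (Homo sapiens) for inhibition, read by colorimetric assay and MTT assay, with a stated time of 72 h; on this read-out lower numbers stand for stronger inhibition and higher numbers for weaker inhibition. Compound 2 differs from compound 1 by methyl in place of hydrogen on an aromatic carbon, and this step is a 1.5-fold lower number from compound 1 to compound 2 (0.17 log units; within the scatter). Compound 3 is built on a different core, and the difference between the two cores is not broken down here; its number stands highest of the three, with both compound 1 and compound 2 giving lower numbers by steps beyond the scatter.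

Compound 4 `Cc1ccc(-c2cc(Nc3nnc(-c4ccc(O)cc4)s3)cs2)cc1` has not yet been measured in this assay. It differs from compound 3 by methyl in place of hydrogen on an aromatic carbon, at a place described in the same words as the step from compound 1 to compound 2, so the change is the same one, now made on the core of compound 3. The step from compound 3 to compound 4 is expected to be a 1.4-fold lower number from compound 3 to compound 4 (0.15 log units; within the scatter), because the earlier one was a 1.5-fold lower number from compound 1 to compound 2 (0.17 log units; within the scatter). Compound 4 is therefore estimated to give about 40000 nM, with the likely range running from 20000 nM to 90000 nM.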

Compound 4, half-maximal inhibitory concentration: 14000 nM
Compound 4: middle estimate off by 2.9-fold (0.46 log units), on the high side; the whole stated range lies above it.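

Placed on the core of compound 3, the change from phenyl to 4-methylphenyl gave a 4.1-fold lower number from compound 3 to compound 4 (0.61 log units; beyond the scatter) in this assay. Only on this core does the step lie beyond the scatter; on the core of compound 1 it stays within it, so the size of the change did not carry from one core to the other: the same change on two cores in this assay, a 1.5-fold lower number (0.17 log units; within the scatter) from compound 1 to compound 2 and a 4.1-fold lower number (0.61 log units; beyond the scatter) from compound 3 to compound 4, 2.8-fold (0.44 log units) apart, beyond the scatter of two such steps. This shows that, for these two cores, the same methyl cannot be assumed to give a step of the same size, but it does not show why the steps differ, and two pairs of compounds give no rule for any further core.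

The compounds shown leave open whether another group at the same place, such as a chlorine atom or an amine, would also give steps that differ between the two cores. They also leave open whether a longer chain, such as ethyl in place of the methyl, would keep the larger step seen on the core of compound 3.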